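Configuration flip at the ring carbon of compound 2

The source may report more compounds than this note shows. Statements on the series, on what has been measured and on what is new or still open speak of the compounds shown alone.

Compound 1 `COc1cc([C@@H]2C[C@@]2(CO)C(=O)Nc2ccccc2)cc(OC)c1OC` gives 43200 nM in a functional assay on A549 cells (Homo sapiens) for cytotoxicity, read by MTT assay, with a stated time of 48 h; a lower number here means a stronger inhibitor, a higher number a weaker inhibitor. Compound 2 `COc1cc([C@H]2C[C@@]2(CO)C(=O)Nc2ccccc2Cl)cc(OC)c1OC` gives > 100000 nM in this assay, and this value is a limit of the assay, not a number. Where compound 2 truly stands is therefore unknown.

Compound 3 `COc1cc([C@@H]2C[C@@]2(CO)C(=O)Nc2ccccc2Cl)cc(OC)c1OC` has the same atoms and bonds as compound 2 and differs only in configuration as drawn: the two compounds have the same atoms and bonds and differ only in configuration as drawn: 1 of 2 stereo elements differ; a stereocentre at a saturated ring carbon is drawn R in compound 2 and S in compound 3. A stereocentre at a saturated ring carbon is drawn R in compound 2 and S in compound 3.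

Among the measured compounds shown here, no measured step isolates such a change, so its size in this assay remains a judgement. A move toward stronger inhibition is expected, though another limit reading is possible. For the measured compounds named here, the only numeric reading, compound 1 at 43200 nM, anchors this expectation. The estimated step is an at least 1.6-fold lower number from compound 2 to compound 3 (0.22 log units; that floor lies within the scatter). For compound 3 the estimated value is 60000 nM, with an expected range of 25000 nM to 120000 nM.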

Compound 3, half-maximal inhibitory concentration: 11400 nM
The estimate for compound 3 lay 5.3-fold (0.72 log units) above the measured number; measured number outside the range, below it.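

In this assay, the configuration at the saturated ring carbon has a clear effect, with an at least 8.7-fold lower number from compound 2 to compound 3 (0.94 log units; beyond the scatter), and this change is assigned to that carbon alone on the following ground: the fact that compounds 2 and 3 differ only in the configuration as drawn

As far as these compounds go, compound 2 gives > 100000 nM, which is a limit of the assay and not a number, so the full size of this step remains unknown.

With the ring carbon drawn S in both compounds, chloro in place of hydrogen on an aromatic carbon can now also be read on its own, as a 3.8-fold lower number from compound 1 to compound 3 (0.58 log units; beyond the scatter).

The compounds shown leave open whether this gain is specific to chloro or also appears with fluoro or a nitrile in its place. They also leave open how the S-drawn series responds when an amine or a carboxylic acid replaces the hydroxymethyl group.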